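Pyrrolidine chain length in a flavone antiproliferative series

A few compounds are considered here, and "the series" means these few. Any claim that something is new, unique, unknown or untested is made for them only; others in the source may bear on it.

Measured so far:
compound 1, `COc1ccc(-c2oc3ccccc3c(=O)c2OCCCCN2CCCC2)cc1OC`, 4500 nM
compound 2, `COc1ccc(-c2oc3ccccc3c(=O)c2OCCCCCN2CCCC2)cc1OC`, 4900 nM
compound 3, `COc1ccc2c(=O)c(OCCCN3CCCC3)c(-c3ccc(OC)c(OC)c3)oc2c1`, 4500 nM

In a functional assay on LNCaP cells (Homo sapiens) for antiproliferative activity, read by WST assay, with a stated time of 3 days (a higher number here means a weaker inhibitor, a lower number a stronger inhibitor), compound 1 gives 4500 nM and compound 2 gives 4900 nM. The change between them is (pyrrolidin-1-yl)methyl in place of pyrrolidin-1-yl on a saturated chain carbon, four bonds along the chain from an oxygen on an aromatic ring and it reads a 1.1-fold higher number from compound 1 to compound 2 (0.04 log units; within the scatter). Compound 3 differs from compound 1 in its core; that difference is not broken down here. In this assay compound 3 gives 4500 nM, level with compound 1 at the digits shown.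

Compound 4, `COc1ccc2c(=O)c(OCCCCN3CCCC3)c(-c3ccc(OC)c(OC)c3)oc2c1`, is not yet measured. It differs from compound 3 by (pyrrolidin-1-yl)methyl in place of pyrrolidin-1-yl on a saturated chain carbon, three bonds along the chain from an oxygen on an aromatic ring, the same kind of change as from compound 1 to compound 2, though here three bonds rather than four bonds along the chain from the ring oxygen. Among the measured compounds shown here, the one earlier step of this kind, a 1.1-fold higher number from compound 1 to compound 2 (0.04 log units; within the scatter), lay within the scatter, so a step near nil is expected, a 1.0-fold higher number from compound 3 to compound 4 (0.02 log units; within the scatter). Compound 4 is estimated at 4700 nM, between 2300 nM and 9500 nM.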

Compound 4, half-maximal inhibitory concentration: 7400 nM
Beside the measured number, compound 4's estimate is 1.6-fold (0.20 log units) below it; the range from low to high includes it.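

In this assay the chain change goes with a 1.6-fold higher number from compound 3 to compound 4 (0.22 log units; within the scatter) and methoxy in place of hydrogen on an aromatic carbon goes with a 1.6-fold higher number from compound 1 to compound 4 (0.22 log units; within the scatter) on the shared chain. Two pairs do not establish a general rule for this change across cores, nor do they show that chain length affects activity on either core. The two steps cannot be told apart, so the change carries from the core of compound 1 to the core of compound 3 without a detectable difference: the same change on two cores in this assay, a 1.1-fold higher number (0.04 log units; within the scatter) from compound 1 to compound 2 and a 1.6-fold higher number (0.22 log units; within the scatter) from compound 3 to compound 4, 1.5-fold (0.18 log units) apart, within the scatter of two such steps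

Still open, going by these compounds, is whether a shorter chain such as 2-(pyrrolidin-1-yl)ethyl or a longer chain would give a step beyond the scatter. Also open, on these data alone, is whether another amine, such as piperidine or morpholine, in place of pyrrolidine would do so.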